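Nitro Gives Way to Dimethylamino

This account rests on a few compounds, and the source may have more. Where it says the series, first, only, none or still open, it means among the compounds named here.

In a functional assay on KB cells (Homo sapiens) for inhibition, with a stated time of 72 h (a lower number here means a stronger inhibitor, a higher number a weaker inhibitor), three compounds sharing one core have been measured. Compound 1 (`COc1ccc(S(=O)(=O)N2CCc3cccc(-c4ccc(N)cc4)c32)cc1`), which carries 4-aminophenyl, gives 249 nM. Compound 2 (`COc1ccc(S(=O)(=O)N2CCc3cccc(-c4ccc(F)nc4)c32)cc1`), which carries 6-fluoropyridin-3-yl, gives 143 nM. Compound 3 (`COc1ccc(S(=O)(=O)N2CCc3cccc(-c4ccc([N+](=O)[O-])cc4)c32)cc1`), which carries 4-nitrophenyl, gives 52.5 nM, the lowest number of the three.

Compound 4 (`COc1ccc(S(=O)(=O)N2CCc3cccc(-c4ccc(N(C)C)cc4)c32)cc1`) has dimethylamino in place of nitro on an aromatic carbon, para to a large group: dimethylamino in place of nitro on an aromatic carbon.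

The closest measured change is a 4.7-fold lower number from compound 1 to compound 3 (0.68 log units; beyond the scatter), with nitro in place of amino. Read backwards, it points to a higher number when nitro leaves. The other two steps bear on this less directly, since each swaps the whole aromatic group. One is a 2.7-fold lower number from compound 2 to compound 3 (0.44 log units; beyond the scatter), which again favours the nitro compound, and the other is a 1.7-fold lower number from compound 1 to compound 2 (0.24 log units; within the scatter). For the measured compounds named here, no dimethylamino compound has been measured, so how closely it will follow amino remains open. A step in the same direction is therefore expected, probably beyond the scatter but somewhat smaller than the amino precedent. The expected change is a 2.5-fold higher number from compound 3 to compound 4 (0.39 log units; beyond the scatter). For compound 4 the estimated value is 130 nM, with an expected range of 45 nM to 400 nM.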

Compound 4, half-maximal inhibitory concentration: 539 nM
The estimate for compound 4 lay 4.1-fold (0.62 log units) below the measured number; measured number outside the range, above it.
By their numbers in this assay, from the lowest: compound 3; then compounds 2 and 1 (each within the scatter of the next); then compound 4.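

In this assay, for the compounds shown here, the aromatic carbon para to a large group proves more sensitive than the earlier compounds indicated: dimethylamino in place of nitro gives the largest step in the set so far (a 10-fold higher number from compound 3 to compound 4 (1.01 log units; beyond the scatter)). The amino precedent did not set the ceiling, since dimethylamino in place of amino raises the number further (a 2.2-fold higher number from compound 1 to compound 4 (0.34 log units; beyond the scatter)), so the two amines are not interchangeable here, and compound 4 also stands clear of the fluoropyridine compound (a 3.8-fold higher number from compound 2 to compound 4 (0.58 log units; beyond the scatter)). The nitro, amino and dimethylamino compounds thus form an ordered series at this one place, with every step beyond the scatter, but nothing available explains that order.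

Going by these compounds, it remains open whether methylamino, with a single methyl on the nitrogen, would fall between amino and dimethylamino, and whether a nitrile or a carboxylic acid at the same place would keep a number close to that of compound 3. Also open, on these data alone, is how much of the gap between the fluoropyridine compound and the others belongs to the fluorine and how much to the ring nitrogen, which a 4-fluorophenyl group could help to separate.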